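A few compounds are considered here, and "the series" means these few. Any claim that something is new, unique, unknown or untested is made for them only; others in the source may bear on it.

Measured compounds in a functional assay on A549 cells (Homo sapiens) for cytotoxicity, read by sulforhodamine B assay, with a stated time of 72 h; a higher number here means a weaker inhibitor, a lower number a stronger inhibitor:
compound 1, `CCS(=O)(=O)Nc1cc(-c2ccc3ncnc(Nc4ccc(F)cc4)c3c2)cnc1OC`: compound 1 gives 7620 nM
compound 2, `CCS(=O)(=O)Nc1cc(-c2ccc3ncnc(Nc4ccc(OC)cc4)c3c2)cnc1OC`: compound 2 gives 3580 nM
compound 3, `COC(=O)c1cccc(Nc2ncnc3ccc(-c4cnc(OC)c(NS(=O)(=O)c5ccc(F)cc5F)c4)cc23)c1`: compound 3 gives 10500 nM

Compound 2 holds the lowest number of the three in this assay. Among the compounds with values here, the only single-point step measured is a 2.1-fold lower number from compound 1 to compound 2 (0.33 log units; beyond the scatter), and compound 1 sits closest to compound 2. Within the data shown here, compound 3 differs from compound 2 in more than one place, so its two values show only that compound 3 sits higher, without a step attached.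

Compound 4, `CCS(=O)(=O)Nc1cc(-c2ccc3ncnc(Nc4ccc(OC)nc4)c3c2)cnc1OC`, differs from compound 2 by 6-methoxypyridin-3-yl in place of 4-methoxyphenyl on a nitrogen on an aromatic ring. Among the measured compounds shown here, no measured step bears on this kind of exchange: the step of a 2.1-fold lower number from compound 1 to compound 2 (0.33 log units; beyond the scatter) changes a group carried on that ring, not the ring itself, and compound 3 offers no single-point comparison. For the measured compounds named here, with no precedent, the expectation for compound 4 in this assay is a step of a 1.1-fold higher number from compound 2 to compound 4 (0.05 log units; within the scatter), within the scatter. Compound 4 is therefore estimated at 4000 nM, with a range of 1500 nM to 12000 nM.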

Compound 4, half-maximal inhibitory concentration: 5560 nM
The estimate for compound 4 lay 1.4-fold (0.14 log units) below the measured number, and the stated range covers the measured number.
By their numbers in this assay, from the lowest: compounds 2, 4, 1 and 3 (each within the scatter of the next, the first and the last beyond it).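

In this assay, within the data shown here, the only exchange of the ring itself on this nitrogen, 6-methoxypyridin-3-yl in place of 4-methoxyphenyl, stays within the scatter (a 1.6-fold higher number from compound 2 to compound 4 (0.19 log units; within the scatter)), so the ring nitrogen gives no separation of compound 4 from compound 2. Set against 4-fluorophenyl, the same group also stays within the scatter (a 1.4-fold lower number from compound 1 to compound 4 (0.14 log units; within the scatter)), even though the earlier group change on the phenyl ring lies just beyond it (a 2.1-fold lower number from compound 1 to compound 2 (0.33 log units; beyond the scatter)), and compound 4 therefore cannot be separated from either neighbour. No measurement in hand offers an explanation for these steps.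

Open, from the compounds shown here alone, is whether an amine or a carboxylic acid in place of the methoxy on the pyridine ring would move the number beyond the scatter. Also open, going by these compounds, is whether 6-fluoropyridin-3-yl would keep the ring exchange within the scatter.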